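A few compounds are considered here, and "the series" means these few. Any claim that something is new, unique, unknown or untested is made for them only; others in the source may bear on it.

Among the measured compounds shown here, compound 1 `C[Se]/C(=N\C(=O)c1ccco1)NC(=O)c1ccco1` gives 360 nM in a functional assay on PC-3 cells (Homo sapiens) for cytotoxicity, read by MTT assay, with a stated time of 72 h (a higher number here means a weaker inhibitor of growth, a lower number a stronger inhibitor of growth), the lowest of the three numbers measured so far. Compound 2 `C[Se]/C(=N\C(=O)c1cccs1)NC(=O)c1cccs1` gives 1340 nM in this assay, and compound 3 `CS/C(=N\C(=O)c1cccs1)NC(=O)c1cccs1` gives 39000 nM. For the measured compounds named here, the single step measured between compounds that differ in one place, a 29-fold higher number from compound 2 to compound 3 (1.46 log units; beyond the scatter), concerns the exchange of a selenium-bearing group for a sulfur-bearing group on the carbon with a double bond to nitrogen. Compound 4 `O=C(/N=C(/NC(=O)c1ccco1)[Se]Cc1ccccc1)c1ccco1` differs from compound 1 by phenyl in place of hydrogen on a saturated chain carbon bound to a selenium atom; cut one bond further out, the change reads methyl to benzyl. Going by the values given here, no measured step bears directly on this change: the selenium atom is kept, and the only available step alters the heteroatom itself rather than what is attached to it. The size and direction of the step are therefore open, with no basis for predicting a move beyond the scatter. Compound 4 is expected to give about 500 nM, within a range from 120 nM to 2500 nM. This estimate corresponds to a step of a 1.4-fold higher number from compound 1 to compound 4 (0.14 log units; within the scatter) that is not expected to exceed the scatter.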

Compound 4, concentration for 50% growth inhibition: 30500 nM
Compound 4: middle estimate off by 61-fold (1.79 log units), on the low side; the measured number lies above the stated range.
By their numbers in this assay, from the lowest: compound 1; then compound 2; then compounds 4 and 3 (each within the scatter of the next).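

The group carried on selenium proves to be far from a silent position: in this assay, phenyl in place of hydrogen on a saturated chain carbon bound to a selenium atom, which reads as methyl to benzyl, gives an 85-fold higher number from compound 1 to compound 4 (1.93 log units; beyond the scatter) as a large step toward weaker inhibition of growth. The earlier step changed the heteroatom itself, whereas this one shows that a large move also occurs with selenium kept and only the group on it changed. No measured evidence on hand bears on why this step is so large.

Only methyl and benzyl are shown on the selenium atom of this core, so it remains open whether an ethyl group, a longer chain or a chain carrying an amine would stay close to compound 1 or compound 4. Also open, from the compounds shown here alone, is whether the same change would have a similar effect on the core of compound 2.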